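The compounds below may be only part of what the source reports. "The series", "measured", "known", "first", "only" and "open" are said of these compounds alone.

The measured compounds:

Compound 1 `O=C(O)c1ccccc1C1CC(c2cc3ccccc3o2)=NN1C(=O)c1ccncc1` gives in an ADME assay on Vero cells (Chlorocebus sabaeus) for cytotoxicity, read by MTT assay, with a stated time of 72 h (a higher number here means a weaker inhibitor, a lower number a stronger inhibitor), a value that is a limit of the assay, > 170000 nM.
Compound 2 `O=C(c1ccncc1)N1N=C(c2cc3ccccc3o2)CC1c1cccc([N+](=O)[O-])c1` gives in this assay a limit as well, > 240000 nM.
Compound 3 `CCn1cc(C(=O)N2N=C(c3cc4ccccc4o3)CC2c2ccccc2C(=O)O)c(=O)c2ccc(C)nc21` likewise gives in this assay only a limit, > 196000 nM.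

None of the three values is a number; each sits at a limit, as the limit of > 170000 nM in this assay, at which 1 of the 3 values shown sits, the limit of > 196000 nM in this assay, at which 1 of the 3 values shown sits, and the limit of > 240000 nM in this assay, at which 1 of the 3 values shown sits, show. The change 3-nitrophenyl in place of 2-carboxyphenyl on a saturated ring carbon therefore produces a step that the two limits leave unreadable from compound 1 to compound 2, a step whose size cannot be read.

Compound 4 `CCn1cc(C(=O)N2N=C(c3cc4ccccc4o3)CC2c2cccc([N+](=O)[O-])c2)c(=O)c2ccc(C)nc21` carries the same kind of change, (3-nitrophenyl in place of 2-carboxyphenyl on a saturated ring carbon), on the core of compound 3. The difference between the core of compound 1 and that of compound 3 is not broken down here; the surroundings of the place also differ in description, the ring atom bearing a (pyridin-4-yl)carbonyl group in compound 1 and a large group in compound 3.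

Since compound 3 gives only a limit in this assay and the step that the two limits leave unreadable from compound 1 to compound 2 is unreadable, compound 4 is expected to give a step that the limit leaves unreadable from compound 3 to compound 4, most likely again a limit. Compound 4 is estimated at 250000 nM, with an expected range from 120000 nM to 1000000 nM.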

Compound 4, half-maximal inhibitory concentration: > 164000 nM
Compound 4: a limit, no number; the forecaster's own chance of this, stated with the estimate: 85%; the middle value is on the limit's open side.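

In this assay compound 4 gives > 164000 nM, which is a limit and not a number. No step can be read from compound 3 to compound 4, just as none can be read from compound 1 to compound 2. The compounds shown leave open what number any of the four would give in this assay, and whether 3-nitrophenyl in place of 2-carboxyphenyl changes it at all.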